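The compounds below may be only part of what the source reports. "The series", "measured", "known", "first", "only" and "open" are said of these compounds alone.

Of the compounds shown here, two built on the same core have been measured in a functional assay on HeLa cells (Homo sapiens) for cytotoxicity, read by MTT assay, with a stated time of 48 h, tested at 12.5 uM; on this read-out higher numbers stand for a stronger effect at the one concentration tested and lower numbers for a weaker effect. Compound 1 `CS(=O)(=O)c1ccc(Cc2n[nH]c(=S)n2/N=C/c2ccc(-c3ccccc3)cc2)cc1` gives 30.4% in this assay. Compound 2 `CS(=O)(=O)c1ccc(Cc2n[nH]c(=S)n2/N=C/c2ccc(Cl)cc2)cc1` gives 44.7% in this assay, the higher of the two numbers. For the measured compounds named here, the only step seen so far, a number 14.3 percentage points higher from compound 1 to compound 2 (beyond the scatter), came from a change on the aromatic ring that hangs from the carbon with a double bond to nitrogen.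

Compound 3 `CS(=O)(=O)c1ccc(Cc2n[nH]c(=S)n2/N=C/c2cccs2)cc1` differs from compound 2 in that same region: thiophen-2-yl in place of 4-chlorophenyl on a carbon with a double bond to nitrogen. Going by the values given here, no measured step covers this kind of exchange, in which the whole six-membered aromatic ring of carbon only gives way to a five-membered aromatic ring with one hetero atom; the single step from compound 1 to compound 2 only shows that changing what sits on that ring can shift the number by a modest amount beyond the scatter. On that basis the expectation for compound 3 is a change of similar or smaller size, with the direction uncertain, expected as a number 8.7 percentage points lower from compound 2 to compound 3 (within the scatter). Compound 3 is therefore estimated at 36% in this assay, with a range from 18% to 54%.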

Compound 3, a percentage reported as activity, at one concentration (the size of the read-out at that concentration, not a potency): 28.7%
Compound 3: middle estimate off by 7.3 percentage points, on the high side, and the stated range covers the measured number.
By their numbers in this assay, from the lowest: compounds 3 and 1 (each within the scatter of the next); then compound 2.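

In this assay there is a number 16 percentage points lower from compound 2 to compound 3 (beyond the scatter) when thiophen-2-yl takes the place of 4-chlorophenyl on a carbon with a double bond to nitrogen, so the number here responds to an exchange of the whole ring, not only to a change in what that ring carries. Compound 2 now stands beyond the scatter from both other compounds, whereas compound 3 at 28.7% and compound 1 at 30.4% lie within the scatter of each other, even though one carries a five-membered ring and the other a six-membered ring bearing phenyl. No measurement at hand explains why the number moves with either change.

With only three groups at this position, the compounds shown leave open whether the higher number of compound 2 belongs to the chlorine or to the six-membered ring that carries it, a question that an unsubstituted phenyl ring or a 4-methoxyphenyl group would address. They also leave open how other five-membered rings, such as furan-2-yl, or rings carrying an amine or a carboxylic acid would compare.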